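This account rests on a few compounds, and the source may have more. Where it says the series, first, only, none or still open, it means among the compounds named here.

Working notes on the series. In a functional assay on MCF7 cells (Homo sapiens) for antiproliferative activity, with a stated time of 5 days (on this read-out higher numbers stand for weaker inhibition and lower numbers for stronger inhibition), compound 1 `CCCCCCc1ccc2[nH]c(-c3ccc(OC)cc3)c(C=O)c2c1` gives 6 nM and compound 2 `CCCCCc1ccc2[nH]c(-c3ccc(C(F)(F)F)cc3)c(C=O)c2c1` gives 67 nM. Compound 2 therefore holds the higher of the two numbers, and the gap to compound 1 lies beyond the usual scatter. With only these two values, compound 2 marks the weaker end of a very small set, and no wider trend can be claimed.

The next entry is compound 3 `CCCCCCc1ccc2[nH]c(-c3ccc(C(F)(F)F)cc3)c(C=O)c2c1`, which differs from compound 2 by methyl in place of hydrogen on a saturated chain carbon, five bonds along the chain from an aromatic carbon. For the measured compounds named here, no pair of measured compounds differs in one place only, so the data give no direct size for such a change in this assay. A small move towards a lower number is expected, probably not beyond the scatter, with the low value of compound 1 at 6 nM as the only weak pull in that direction. The estimated 1.5-fold lower number from compound 2 to compound 3 (0.17 log units; within the scatter) is correspondingly modest. For compound 3 the expected value is 45 nM, with an estimated range of 15 nM to 130 nM.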

Compound 3, half-maximal inhibitory concentration: 22 nM
Beside the measured number, compound 3's estimate is 2.0-fold (0.31 log units) above it; measured number inside the range.
By their numbers in this assay, from the lowest: compound 1; then compound 3; then compound 2.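

In this assay, for the compounds shown here, methyl in place of hydrogen on a saturated chain carbon, five bonds along the chain from an aromatic carbon, gives a 3.0-fold lower number from compound 2 to compound 3 (0.48 log units; beyond the scatter), which is the first direct size for a change at this position and shows that this single added methyl is enough to move the number beyond the scatter. Compound 3 also provides a second comparison in one place, on an aromatic carbon: trifluoromethyl in place of methoxy gives a 3.7-fold higher number from compound 1 to compound 3 (0.56 log units; beyond the scatter), again a modest step beyond the scatter, so the result responds to both the chain and the aromatic group. No accompanying measurement bears on the cause of either step.

From the compounds shown here alone, each change is seen only once, so it remains open whether the methyl step keeps its size with methoxy on the aromatic carbon, or whether the trifluoromethyl step keeps its size on other chains. Also open, going by these compounds, is how a longer chain, or a chain carrying an amine or a carboxylic acid, would read in this assay, so no trend along the chain can be stated.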